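The source may hold more compounds than are shown below. What is called first, only, known or untested is meant among the compounds shown, and "the series" means these compounds.

Of the compounds shown here, three that share one core have been tested in a functional assay on cells (Homo sapiens) for cytotoxicity; on this read-out higher numbers stand for weaker inhibition and lower numbers for stronger inhibition. Compound 1 (`Cc1cn([C@@H]2C=C[C@H](CO)C2)c(=O)[nH]c1=O`) gives 66600 nM. Compound 2 (`O=c1ccn([C@@H]2C=C[C@H](CO)C2)c(=O)[nH]1`) gives > 100000 nM, which is a limit of the assay and not a number. Compound 3 (`Cc1cn(C2CCC(CO)C2)c(=O)[nH]c1=O`) gives > 100000 nM, which is also a limit and not a number. Its standing is therefore known only as the limit of > 100000 nM in this assay, at which 2 of the 3 values shown sit.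

Compound 4 (`O=c1ccn(C2CCC(CO)C2)c(=O)[nH]1`) has not yet been measured. It differs from compound 3 by hydrogen in place of methyl on an aromatic carbon. For the measured compounds named here, the same change has been measured once, and that single step is the only guide: an at least 1.5-fold higher number from compound 1 to compound 2 (0.17 log units; that floor lies within the scatter). Compound 2 ends at a limit, so this step gives a floor and not a full size. On that evidence, a step of similar small size toward higher numbers, not clearly beyond the scatter, is expected in this assay. The estimated step is a step that the limit leaves unreadable from compound 3 to compound 4. For compound 4 the expected value is 150000 nM, with an estimated range from 90000 nM to 300000 nM. The most likely outcome is that this assay again reports only a limit.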

Compound 4, half-maximal inhibitory concentration: > 100000 nM
Compound 4: a limit, no number; the forecaster's own chance of this, stated with the estimate: 90%; the middle value lies beyond the limit too.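

In this assay compound 4 gives > 100000 nM, which is a limit and not a number. For the compounds shown here, compound 3 also stands at a limit, so no step between compound 3 and compound 4 can be read. The compounds shown leave open the actual numbers of compound 2, compound 3 and compound 4, which all stand at the same mark: the limit of > 100000 nM in this assay, at which 3 of the 4 values shown sit.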